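Benzyl to thian-4-yl in a rat dose assay

The source may report more compounds than this note shows. Statements on the series, on what has been measured and on what is new or still open speak of the compounds shown alone.

compound 1 `CC(C)c1ccc(OC(C)(Cc2cccc(C(F)(F)F)c2)C(=O)O)cc1` gives 5 mg/kg
compound 2 `CC(Cc1ccc(Cl)cc1)(Oc1ccc(Cc2ccccc2)cc1)C(=O)O` gives 1 mg/kg

In a functional assay on the whole organism for inhibition, with Rattus norvegicus as the target (a lower number here means that less compound is needed, a higher number that more compound is needed for the effect), compound 2 stands at the lower of the two numbers, 1 mg/kg, while compound 1 needs more, at 5 mg/kg, a gap beyond the usual scatter. Compound 3 `CC(Cc1ccc(Cl)cc1)(Oc1ccc(C2CCSCC2)cc1)C(=O)O` has thian-4-yl in place of benzyl on an aromatic carbon, para to a large group: thian-4-yl in place of benzyl on an aromatic carbon. Among the compounds with values here, no measured pair shows the effect of a single change, so the expectation rests on little. Within the data shown here, compound 2 holds the lowest number so far at 1 mg/kg, and a moderate move towards a higher number in this assay is therefore expected rather than a further fall. The expected size of this change is a 2.5-fold higher number from compound 2 to compound 3 (0.40 log units; beyond the scatter). The estimate for compound 3 is 2.5 mg/kg, with an expected range from 0.7 mg/kg to 9 mg/kg.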

Compound 3, dose for half-maximal effect: < 10 mg/kg
Compound 3 gave a limit, no number; the forecaster's own chance of this, stated with the estimate: 5%; the middle value does not contradict the limit.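

In this assay compound 3 gave only a limit, < 10 mg/kg, so the step from compound 2 to compound 3 cannot be read. The compounds shown leave open whether thian-4-yl in place of benzyl raises, lowers or leaves unchanged the dose needed.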